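Carboxy in place of dimethylamino on the fused ring

A few compounds are considered here, and "the series" means these few. Any claim that something is new, unique, unknown or untested is made for them only; others in the source may bear on it.

Among the measured compounds shown here, compound 2 `CN(C)c1c(F)c(N)c2c(=O)cc(-c3ccc(N)c(F)c3)oc2c1F` holds the lowest of the two numbers measured so far: in a functional assay on MCF7 cells (Homo sapiens) for cytotoxicity, read by neutral red uptake, with a stated time of 3 days (on this read-out higher numbers stand for weaker inhibition and lower numbers for stronger inhibition), compound 2 gives 39 nM. For the measured compounds named here, its nearest neighbour is compound 1 `Nc1ccc(-c2cc(=O)c3c(N)c(F)c(Cl)c(F)c3o2)cc1F`, which in this assay gives 210 nM; the single step between them, a 5.4-fold lower number from compound 1 to compound 2 (0.73 log units; beyond the scatter), is the only measured change at this position of the shared core.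

Compound 3 `Nc1ccc(-c2cc(=O)c3c(N)c(F)c(C(=O)O)c(F)c3o2)cc1F` is not yet measured. The change from compound 2 is carboxy in place of dimethylamino on an aromatic carbon. The measured step compares chloro with dimethylamino, not dimethylamino with carboxy, so it bears on the new step only in showing that this position can move the number well beyond the scatter. Going by the values given here, no measured step exchanges any group for a carboxy group, and nothing shows a carboxy group at all, so the direction rests on the fact that compound 2 is the best point seen and that a further gain would be an extrapolation. For compound 3 the expected step is therefore an upward one, a 7.7-fold higher number from compound 2 to compound 3 (0.89 log units; beyond the scatter), with wide uncertainty. Compound 3 is expected to give about 300 nM in this assay, within a range from 60 nM to 1500 nM.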

Compound 3, half-maximal inhibitory concentration: > 10000 nM
Compound 3 was reported as a limit; the forecaster's own chance of this, stated with the estimate: 5%; at least 33-fold (1.52 log units) between middle value and limit.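

Compound 3 stands in this assay as a limit and not as a number: the limit of > 10000 nM in this assay, at which 1 of the 3 values shown sits.

The earlier compounds shown here showed only that this aromatic carbon can shift the read-out, with a 5.4-fold lower number from compound 1 to compound 2 (0.73 log units; beyond the scatter) between chloro and dimethylamino. Carboxy shows that the same carbon can also take the series out of the measurable range, with an at least 250-fold higher number from compound 2 to compound 3 (2.40 log units; beyond the scatter) and, against the chloro compound, an at least 47-fold higher number from compound 1 to compound 3 (1.67 log units; beyond the scatter). Dimethylamino and carboxy carry the same number of heavy atoms, so heavy-atom count does not separate these two groups here, whereas the hydrogen-bond donor count does, since carboxy brings one and dimethylamino none.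

The three compounds do not tell which feature of the carboxy group goes with the loss, and a single exchange at a single position supports no general rule. Going by these compounds, whether a methyl ester or a primary amide on this carbon would stay near compound 2 or fall with compound 3 remains open, as does whether a smaller amine such as methylamino would match dimethylamino.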